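Chloro in place of methyl at compound 4

The compounds below may be only part of what the source reports. "The series", "measured", "known", "first", "only" and "open" are said of these compounds alone.

In a functional assay on LoVo cells (Homo sapiens) for inhibition, read by MTT assay, with a stated time of 48 h (on this read-out lower numbers stand for stronger inhibition and higher numbers for weaker inhibition), compound 1 (`C[Se]c1ccc(N(C)c2nc(C3CC3)nc3ccccc23)cc1`) gives 11 nM and compound 3 (`COc1ccc(N(C)c2nc(C)nc3ccccc23)cc1OCC[Se]C#N`) gives 19 nM while compound 2 (`Cc1nc(N(C)c2ccc([Se]C#N)c(C)c2)c2ccccc2n1`) gives 19 nM and so stands level with compound 3. None of the three values lies beyond the usual scatter from another. Compound 4 (`Cc1nc(N(C)c2ccc([Se]C#N)c(Cl)c2)c2ccccc2n1`) differs from compound 2 by chloro in place of methyl on an aromatic carbon and thus carries chloro in place of methyl on an aromatic carbon. Among the compounds with values here, no measured pair shows this swap, so the evidence for it is thin. The estimated 1.3-fold lower number from compound 2 to compound 4 (0.10 log units; within the scatter) stays within the scatter in this assay with no firm direction expected. Compound 4 is expected at 15 nM (estimated range 6 nM to 40 nM).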

Compound 4, half-maximal inhibitory concentration: 12 nM
Compound 4: the middle estimate sits 1.3-fold (0.10 log units) above what was measured, within the range that was stated.
By their numbers in this assay, from the lowest: compounds 1, 4, 2 and 3 (each within the scatter of the next).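

Chloro in place of methyl on an aromatic carbon, ortho to a group of 3 heavy atoms, now has a measured pair, and it gives a 1.6-fold lower number from compound 2 to compound 4 (0.20 log units; within the scatter) in this assay. At this position, the two groups are therefore not told apart by this read-out. Nothing available explains this result. From the compounds shown here alone, whether an amine or a carboxylic acid on this aromatic carbon would stand apart from methyl and chloro remains open. So does whether this swap would give the same result with the other groups on the core changed.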